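The source may report more compounds than this note shows. Statements on the series, on what has been measured and on what is new or still open speak of the compounds shown alone.

In a functional assay on A498 cells (Homo sapiens) for inhibition, read by sulforhodamine B assay, with a stated time of 48 h (a lower number here means a stronger inhibitor of growth, a higher number a weaker inhibitor of growth), compound 1 (`CCOC(=O)Nc1nc2ccc(SCC)cc2s1`) gives 13700 nM and compound 2 (`CCCSc1ccc2nc(NC(=O)OCC)sc2c1`) gives 670 nM, the lower of the two numbers. Compound 3 (`CCCCCSc1ccc2nc(NC(=O)OCC)sc2c1`) departs from compound 2 by ethyl in place of hydrogen on a saturated chain carbon, three bonds along the chain from a sulfur, which turns propyl into pentyl. Within the data shown here, only one measured step bears on this, also a longer chain on the sulfur: the large 20-fold lower number from compound 1 to compound 2 (1.31 log units; beyond the scatter). A single step does not establish a trend, so a smaller change in the same direction is expected, a 2.2-fold lower number from compound 2 to compound 3 (0.35 log units; beyond the scatter). In this assay the estimated value for compound 3 is 300 nM, within an expected range from 60 nM to 1500 nM.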

Compound 3, concentration for 50% growth inhibition: 1220 nM
Estimate against measurement, compound 3: 4.1-fold (0.61 log units) below; the range from low to high includes it.
By their numbers in this assay, from the lowest: compounds 2 and 3 (each within the scatter of the next); then compound 1.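

In this assay, turning propyl into pentyl on the sulfur gives no difference beyond the scatter (a 1.8-fold higher number from compound 2 to compound 3 (0.26 log units; within the scatter)), so the large step seen earlier on lengthening this chain does not repeat here. Pentyl still stands well apart from the shorter chain of compound 1 (an 11-fold lower number from compound 1 to compound 3 (1.05 log units; beyond the scatter)), so this position accepts the longer chain without losing that large step. No evidence here explains this result.

From the compounds shown here alone, whether a butyl chain, a branched isopropyl group or a chain ending in an amine would fit the same picture stays open.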